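From a dimethylphenyl to a cyanophenyl on the shared core

This account rests on a few compounds, and the source may have more. Where it says the series, first, only, none or still open, it means among the compounds named here.

compound 1 `COC(=O)C1=C(C)N=C(C)/C(=C(\O)OC)C1c1cccc(N)c1`: 2000 nM
compound 2 `COC(=O)C1=C(C)N=C(C)/C(=C(\O)OC)C1c1cc(C)ccc1C`: 100 nM

Both compounds were tested in a functional assay (muscle tissue) with Cavia porcellus as the target; on this read-out higher numbers stand for an effect only at larger amounts of compound and lower numbers for an effect already at smaller amounts. Of the two, compound 2 holds the lower number, at 100 nM, while compound 1 stands at 2000 nM.

The compound still awaiting measurement, compound 3 `COC(=O)C1=C(C)N=C(C)/C(=C(\O)OC)C1c1ccc(C#N)cc1`, keeps the shared core but carries 4-cyanophenyl in place of 2,5-dimethylphenyl on a saturated ring carbon. Within the data shown here, only one measured step bears on this change, and it falls at the same ring carbon: a 20-fold lower number from compound 1 to compound 2 (1.30 log units; beyond the scatter). That step shows that exchanging one substituted phenyl for another here can move the number in this assay by a wide margin. Neither measured compound carries a nitrile, so the step informs the likely size more than the direction. Among the measured compounds shown here, a rise is nevertheless expected, since the group leaving is the one found in compound 2 at 100 nM, the lower of the two numbers. The expected change is a 10-fold higher number from compound 2 to compound 3 (1.00 log units; beyond the scatter). For compound 3 the estimated value is 1000 nM, with an expected range from 200 nM to 5000 nM.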

Compound 3, half-maximal effective concentration: 3470 nM
Estimate against measurement, compound 3: 3.5-fold (0.54 log units) below; low and high end bracket the measured number.
By their numbers in this assay, from the lowest: compound 2; then compounds 1 and 3 (each within the scatter of the next).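

In this assay the exchange on this saturated ring carbon produces a 35-fold higher number from compound 2 to compound 3 (1.54 log units; beyond the scatter) and so gives a second large step at this position, this time starting from the 2,5-dimethylphenyl group. The 4-cyanophenyl and 3-aminophenyl groups, by contrast, are not separated by this read-out: the change between them is a 1.7-fold higher number from compound 1 to compound 3 (0.24 log units; within the scatter) even though the two groups differ in their substituent and in how it is named on the phenyl ring. Of the three aryl groups shown, the 2,5-dimethylphenyl group is therefore the only one whose number stands apart from the others beyond the scatter, and nothing available speaks to what lies behind this difference.

The compounds shown leave open whether both methyl groups of the 2,5-dimethylphenyl group are needed for the lower number, as none of them carries a single methyl group, as in 2-methylphenyl or 3-methylphenyl, on this ring carbon. Also open, on these data alone, is where an unsubstituted phenyl or a 3-cyanophenyl group would fall in this assay relative to these three compounds.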